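The source may hold more compounds than are shown below. What is called first, only, known or untested is meant among the compounds shown, and "the series" means these compounds.

Compound 1 `COc1ccc(Nc2ncc(C(F)(F)F)c(N3Cc4cccc(N(C)S(C)(=O)=O)c4C3)n2)cc1C(F)(F)F`: > 30000 nM
Compound 2 `CN(c1cccc2c1CN(c1nc(Nc3cc(C(F)(F)F)cc(C(F)(F)F)c3)ncc1C(F)(F)F)C2)S(C)(=O)=O`: 10300 nM

In a functional assay on HepG2 cells (Homo sapiens) for antiproliferative activity, read by spectrophotometry, with a stated time of 2 days (a higher number here means a weaker inhibitor of growth, a lower number a stronger inhibitor of growth), compound 1 gives > 30000 nM, which is a limit of the assay and not a number (the limit of > 30000 nM in this assay, at which 1 of the 2 values shown sits). In this assay compound 2 gives 10300 nM. Compound 1 therefore stands at the limit, with no number of its own yet. Compound 3 `Cc1cc(Cl)ccc1Nc1ncc(C(F)(F)F)c(N2Cc3cccc(N(C)S(C)(=O)=O)c3C2)n1` differs from compound 1 by 4-chloro-2-methylphenyl in place of 4-methoxy-3-(trifluoromethyl)phenyl on a nitrogen on an aromatic ring. Among the measured compounds shown here, no measured pair covers this change, so its size is unknown. Starting from a limit, the expected step from compound 1 to compound 3 is an at least 1.5-fold lower number from compound 1 to compound 3 (0.17 log units; that floor lies within the scatter), modest, toward stronger inhibition, and possibly not beyond the scatter. Compound 3 is estimated at 20000 nM, within 5000 nM to 60000 nM.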

Compound 3, concentration for 50% growth inhibition: 19600 nM
Compound 3: middle estimate off by 1.0-fold (0.01 log units), on the high side, within the range that was stated.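

On the nitrogen on an aromatic ring, 4-chloro-2-methylphenyl in place of 4-methoxy-3-(trifluoromethyl)phenyl brings a measurable value in this assay, with compound 3 at 19600 nM. The change reads only as an at least 1.5-fold lower number from compound 1 to compound 3 (0.18 log units; that floor lies within the scatter). Its full size cannot be read because compound 1 has only a limit of the assay and no number of its own: the limit of > 30000 nM in this assay, at which 1 of the 3 values shown sits.

Going by these compounds, the chlorine and the methyl enter together, and their separate shares remain open. Also open, on these data alone, is how a phenyl carrying an amine or a carboxylic acid would read at this place.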